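Chain extension on the core of compound 1

This account rests on a few compounds, and the source may have more. Where it says the series, first, only, none or still open, it means among the compounds named here.

Compound 1 `CCCc1cn([C@H]2C[C@@H]3OP(=O)(O)OC[C@H]3O2)c(=O)[nH]c1=O` carries a propyl chain on its core. In a functional assay on L1210 cells (Mus musculus) (a lower number here means a stronger inhibitor, a higher number a weaker inhibitor), compound 1 gives > 500 ug/mL, which is a limit of the assay and not a number. Among the compounds with values here, it is the one value of the three that sits at the limit of > 500 ug/mL in this assay, at which 1 of the 3 values shown sits. The open-chain compounds with longer chains give numbers: compound 2 `CCCCCCCCc1cn([C@H]2C[C@H](O)[C@@H](CO)O2)c(=O)[nH]c1=O` gives 72 ug/mL in this assay, and compound 3 `CCCCCCc1cn([C@H]2C[C@H](O)[C@@H](CO)O2)c(=O)[nH]c1=O` gives 195 ug/mL. Within the data shown here, the only measured step, a 2.7-fold higher number from compound 2 to compound 3 (0.43 log units; beyond the scatter), runs toward the higher number when the chain is shortened. Compound 4 `CCCCc1cn([C@H]2C[C@@H]3OP(=O)(O)OC[C@H]3O2)c(=O)[nH]c1=O` differs from compound 1 by methyl in place of hydrogen on a saturated chain carbon, three bonds along the chain from an aromatic carbon, a lengthening of the chain, so the measured step bears on it in the opposite direction and points to a lower number, of about the same modest size. Since compound 1 stands only at a limit, compound 4 is expected to stay near that limit, with an at least 1.4-fold lower number from compound 1 to compound 4 (0.15 log units; that floor lies within the scatter) as the expected step. The estimate for compound 4 is 350 ug/mL, in the range 120 ug/mL to 1000 ug/mL.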

Compound 4, concentration for 50% inhibition: 33.5 ug/mL
Compound 4: the middle estimate sits 10-fold (1.02 log units) above what was measured; measured number below the stated range.
By their numbers in this assay, from the lowest: compound 4; then compound 2; then compound 3. At a limit, above all of these: compound 1.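

Within the data shown here, on the core of compound 1, going from propyl to butyl gives the first step that starts from the limit compound and ends on a number in this assay: an at least 14-fold lower number from compound 1 to compound 4 (1.17 log units; beyond the scatter). Among these compounds, compound 1 stands at a limit of the assay and not at a number, so the size of this step is only a floor: the limit of > 500 ug/mL in this assay, at which 1 of the 4 values shown sits A single methyl in place of hydrogen, on a saturated chain carbon three bonds along the chain from an aromatic carbon, thus carries a large step on this core, whereas the one earlier step, a 2.7-fold higher number from compound 2 to compound 3 (0.43 log units; beyond the scatter), was modest and belonged to the open-chain compounds.

Going by these compounds, whether a pentyl or a longer chain on this core lowers the number further or reverses the trend remains open. Also open, on these data alone, are the effect of an amine or a carboxylic acid on the butyl chain and how the two cores compare at one chain length.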